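Adding a methoxy group to compound 2

The source may report more compounds than this note shows. Statements on the series, on what has been measured and on what is new or still open speak of the compounds shown alone.

Of the compounds shown here, two have been measured in a functional assay on Jurkat cells (Homo sapiens) for cytotoxicity, read by MTT assay, with a stated time of 72 h; a higher number here means a weaker inhibitor, a lower number a stronger inhibitor. Compound 1 (`COc1ccc(NC(=O)Nc2ccc(C(=O)NO)cc2)cc1`) gives 8030 nM, and compound 2 (`O=C(/C=C/c1ccc(NC(=O)Nc2ccccc2)cc1)NO`) gives 160 nM. Compound 2 therefore has the lower of the two numbers, making it the stronger inhibitor, and the gap between the two lies beyond the usual scatter.

Compound 3 (`COc1ccc(NC(=O)Nc2ccc(/C=C/C(=O)NO)cc2)cc1`) has yet to be measured in this assay. It differs from compound 2 in one place: methoxy in place of hydrogen on an aromatic carbon. Put simply, methoxy stands in place of hydrogen on an aromatic carbon, which turns phenyl to 4-methoxyphenyl. Among the measured compounds shown here, no pair of measured compounds shows this change on its own, so the data offer no direct guide to its size. With that uncertainty in mind, a modest outcome is the working expectation, with no step beyond the scatter in either direction in this assay. The expected step, a 1.3-fold higher number from compound 2 to compound 3 (0.10 log units; within the scatter), is accordingly small. For compound 3 the estimated value is 200 nM, with an expected range of 70 nM to 550 nM.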

Compound 3, half-maximal inhibitory concentration: 110 nM
Beside the measured number, compound 3's estimate is 1.8-fold (0.26 log units) above it; low and high end bracket the measured number.
By their numbers in this assay, from the lowest: compounds 3 and 2 (each within the scatter of the next); then compound 1.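

In this assay, methoxy in place of hydrogen on an aromatic carbon, para to a large group, gives a 1.5-fold lower number from compound 2 to compound 3 (0.16 log units; within the scatter), so this position accepts the change from phenyl to 4-methoxyphenyl without a readable shift in the number. Among the compounds shown here, the first single-change comparison at the other end of the molecule comes from compound 1 and compound 3, which share the 4-methoxyphenyl group: 2-(hydroxycarbamoyl)ethenyl in place of hydroxycarbamoyl gives a 73-fold lower number from compound 1 to compound 3 (1.86 log units; beyond the scatter), a step beyond the scatter, whereas the methoxy step is not. No available evidence bears on what lies behind either step.

Going by these compounds, it remains open whether this position would tolerate other groups in the same way, such as a chlorine atom, an amine, a carboxylic acid or a longer alkoxy chain, or whether methoxy would read the same at another carbon of the ring. Also open, on these data alone, is whether the large step tied to the 2-(hydroxycarbamoyl)ethenyl group would recur with plain phenyl in place of 4-methoxyphenyl, and how a saturated two-carbon link or a longer chain ending in the hydroxycarbamoyl group would compare.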